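Same Atoms, Joined Differently, on a Carbonyl Carbon

This account rests on a few compounds, and the source may have more. Where it says the series, first, only, none or still open, it means among the compounds named here.

Among the compounds with values here, in an ADME assay on microsomes from liver (Mus musculus) for metabolic stability, read by LC-MS, with a stated time of 30 min, tested at 1 uM (on this read-out higher numbers stand for a more stable compound and lower numbers for a less stable compound), compound 1 `O=C(NCc1ccc(S(=O)(=O)c2ccccc2)cc1)c1cn2ccnc2cn1` gives 13%, while compound 2 `O=C(NCc1ccc(S(=O)(=O)c2ccccc2)cc1)c1ccc2nncn2c1` gives 47%, the higher of the two numbers so far. Compound 3 `O=C(NCc1ccc(S(=O)(=O)c2ccccc2)cc1)c1cnc2nccn2c1` has not yet been measured. Its difference from compound 2 is this: a group of 9 heavy atoms (6 carbon, 3 nitrogen; one five-membered aromatic ring with 2 hetero atoms, one six-membered aromatic ring with 2 hetero atoms) in place of a group of 9 heavy atoms (6 carbon, 3 nitrogen; one five-membered aromatic ring with 3 hetero atoms, one six-membered aromatic ring with 1 hetero atom), on a carbonyl carbon. The two have the same atoms, joined differently, and the change sits on a carbonyl carbon whose other neighbour is an amide-type nitrogen. Within the data shown here, only one measured step bears on it, a large one: a number 34 percentage points higher from compound 1 to compound 2 (beyond the scatter). That step brought in the group that compound 3 gives up. The group it removed has the same ring count as the group in compound 3, though the two need not be identical, so only part of that step is expected to reverse. In this assay a downward move is therefore expected, smaller than the step to compound 2 but probably beyond the scatter. The expected change is a number 21 percentage points lower from compound 2 to compound 3 (beyond the scatter). Compound 3 is estimated at 26%, with an expected range from 9% to 48%.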

Compound 3, percent of the compound remaining: 30%
The estimate for compound 3 lay 4 percentage points below the measured number; measured number inside the range.
By their numbers in this assay, from the lowest: compound 1; then compound 3; then compound 2.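

With the atoms unchanged and only their joining altered on the carbonyl carbon, this assay records a number 17 percentage points lower from compound 2 to compound 3 (beyond the scatter), so the group in compound 2 is not interchangeable with its isomer at this position. The second comparison is sharper. The groups in compound 1 and compound 3 share the same description, one five-membered aromatic ring with 2 hetero atoms and one six-membered aromatic ring with 2 hetero atoms, yet the record shows a number 17 percentage points higher from compound 1 to compound 3 (beyond the scatter). Neither the atom count nor the hetero atoms counted in each ring therefore settles the number at this carbonyl carbon, since the way the atoms are joined alone separates all three compounds, and nothing available here accounts for these differences.

The three groups hold the same atoms, which leaves open how the read-out would respond to a group with different atoms on the carbonyl carbon, such as an added methyl, a fluorine or an amine. On these data alone, it also remains open whether the same ranking of the three groups would hold if the phenylsulfonyl part of the molecule were replaced by a carboxylic acid.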